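From 3,5-dimethylphenyl to 2,5-dimethylphenyl on a sulfonamide nitrogen

This account rests on a few compounds, and the source may have more. Where it says the series, first, only, none or still open, it means among the compounds named here.

Compound 1 `CCc1ccc(NS(=O)(=O)c2ccc(N3CCNC3=O)cc2)cc1` gives 480 nM
Compound 2 `Cc1cc(C)cc(NS(=O)(=O)c2ccc(N3CCNC3=O)cc2)c1` gives 63 nM

Within the data shown here, in a functional assay on M21 cells (Homo sapiens) for antiproliferative activity, read by sulforhodamine B assay, with a stated time of 48 h (a higher number here means a weaker inhibitor, a lower number a stronger inhibitor), compound 2 gives 63 nM, the lower of the two numbers so far, and compound 1 stands at 480 nM. Among the measured compounds shown here, the only measured step is a 7.6-fold lower number from compound 1 to compound 2 (0.88 log units; beyond the scatter), with 3,5-dimethylphenyl in place of 4-ethylphenyl on a sulfonamide nitrogen.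

Compound 3 `Cc1ccc(C)c(NS(=O)(=O)c2ccc(N3CCNC3=O)cc2)c1` has not yet been measured. It keeps the shared core and has the same atoms as compound 2, joined differently, with 2,5-dimethylphenyl in place of 3,5-dimethylphenyl on a sulfonamide nitrogen. The measured step bears on this change only indirectly, showing that exchanging the group at this place moved the number in these two compounds. Neither measured compound carries 2,5-dimethylphenyl, so the data do not settle the direction. For the measured compounds named here, with compound 2 at 63 nM, the lower of only two numbers, the expectation leans modestly upward. The expected change is a 1.9-fold higher number from compound 2 to compound 3 (0.28 log units; within the scatter), estimated to be smaller than the measured step. For compound 3 the estimated value is 120 nM, with an expected range from 35 nM to 450 nM.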

Compound 3, half-maximal inhibitory concentration: 27 nM
The estimate for compound 3 lay 4.4-fold (0.65 log units) above the measured number, and the stated range ends above it.
By their numbers in this assay, from the lowest: compound 3; then compound 2; then compound 1.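

In this assay, the arrangement of the two methyl groups on the phenyl ring proves to matter in its own right: with the same atoms joined differently, there is a 2.3-fold lower number from compound 2 to compound 3 (0.37 log units; beyond the scatter), so this position responds to a rearrangement that adds and removes nothing. The earlier step could not show this, since it exchanged 4-ethylphenyl for a differently arranged group and left open how much depended on the arrangement alone. Measured against the 4-ethylphenyl group, the new 2,5-dimethylphenyl group gives an 18-fold lower number from compound 1 to compound 3 (1.25 log units; beyond the scatter), the widest gap among the three compounds, but nothing at hand offers an explanation for either shift.

From the compounds shown here alone, all three compounds carry only methyl or ethyl groups on this phenyl ring, so it remains open whether a methoxy group, a chlorine atom, a carboxylic acid or a longer chain would be tolerated there. Going by these compounds, whether the same order would hold with a change to the shared core, or in cells other than these, also remains open.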